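A few compounds are considered here, and "the series" means these few. Any claim that something is new, unique, unknown or untested is made for them only; others in the source may bear on it.

Three compounds built on one shared core have been put into an ADME assay on MOLT-3 cells (Homo sapiens) for cytotoxicity, with a stated time of 7 days; on this read-out higher numbers stand for lower toxicity in this test and lower numbers for higher toxicity in this test. Compound 2 `CCCCCOc1nc(N)nc2c1ncn2/C=C1/CC1(CO)CO` is the only one with a reported result, and that result is a limit rather than a number: compound 2 gave > 20000 nM. Compound 1 `CCCNc1nc(N)nc2c1ncn2/C=C1/CC1(CO)CO` is recorded in this assay as "not determined" (no result reported), and compound 3 `CN(C)c1nc(N)nc2c1ncn2/C=C1/CC1(CO)CO` is recorded there as "not determined" (no result reported). Among the measured compounds shown here, compound 2 therefore stands at the limit of > 20000 nM in this assay, at which 1 of the 3 values shown sits, and no step between two measured compounds can be drawn. Compound 4 `Nc1nc(SCc2ccccc2)c2ncn(/C=C3/CC3(CO)CO)c2n1` differs from compound 2 by benzylsulfanyl in place of pentyloxy on an aromatic carbon. For the measured compounds named here, with no measured step to lean on, the step that the limit leaves unreadable from compound 2 to compound 4 is expected to be no change beyond the scatter. Compound 4 is estimated to give 25000 nM, within a range from 10000 nM to 60000 nM.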

Compound 4, half-maximal cytotoxic concentration: > 20000 nM
Compound 4 gave a limit, no number; the forecaster's own chance of this, stated with the estimate: 75%; the middle value lies beyond the limit too.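

Compound 2 and compound 4 each give only a limit, so no step between them can be read in this assay: the limit of > 20000 nM in this assay, at which 2 of the 4 values shown sit.

The compounds shown leave open at what concentration, if any, compounds on this shared core become toxic to these cells.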